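This account rests on a few compounds, and the source may have more. Where it says the series, first, only, none or still open, it means among the compounds named here.

Measured compounds:
compound 1, `CN(C)c1ccc(C2CC(c3ccc(-n4cncn4)cc3)=NN2S(=O)(=O)c2ccc(F)cc2)cc1`, inhibition 24.1%
compound 2, `CN(C)c1ccc(C2CC(c3ccc(-n4cncn4)cc3)=NN2S(=O)(=O)c2ccc(C(F)(F)F)cc2)cc1`, inhibition 37%
compound 3, `C=C(C)C(=O)N1N=C(c2ccc(-n3ccnc3)cc2)CC1c1ccc(N(C)C)cc1`, inhibition 1.6%

In a functional assay on HCC1806 cells (Homo sapiens) for inhibition, read by sulforhodamine B assay, tested at 10 uM (on this read-out lower numbers stand for less inhibition and higher numbers for more inhibition at the one concentration tested (going by the name of the read-out)), compound 3 stands lowest of the three numbers: compound 1 lies above it beyond the scatter, and compound 2 lies further above it, also beyond the scatter. Compound 4 is `CN(C)c1ccc(C2CC(c3ccc(-n4ccnc4)cc3)=NN2S(C)(=O)=O)cc1`. It differs from compound 3 in one place: methylsulfonyl in place of (1-methylethenyl)carbonyl on an amine nitrogen in a ring. Going by the values given here, the one measured step, a number 12.9 percentage points higher from compound 1 to compound 2 (beyond the scatter), exchanges trifluoromethyl for fluoro on an aromatic carbon of the group carried through the sulfonyl; it does not test the exchange of a carbonyl group for a sulfonyl group on the ring nitrogen, so no measured step bears directly on the change from compound 3 to compound 4. Compounds 1 and 2 do carry a sulfonyl on that ring nitrogen and both show more inhibition than compound 3, but they differ from compound 3 in a second place as well, so their numbers only hint that the sulfonyl is compatible with a higher reading. Compound 4 is therefore expected to give 14%, within a range of 0% to 32%. The expected step, a number 12.4 percentage points higher from compound 3 to compound 4 (beyond the scatter), is estimated to be upward but small, close to the scatter.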

Compound 4, a percentage reported as inhibition, at one concentration (the size of the read-out at that concentration, not a potency): 11.3%
The estimate for compound 4 lay 2.7 percentage points above the measured number, and the stated range covers the measured number.
By their numbers in this assay, from the lowest: compounds 3 and 4 (each within the scatter of the next); then compound 1; then compound 2.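

In this assay, going by these compounds alone, the exchange of (1-methylethenyl)carbonyl for methylsulfonyl on the amine nitrogen in the ring gives a number 9.7 percentage points higher from compound 3 to compound 4 (within the scatter), and this is the first direct test of what sits at this position. Within the data shown here, the only earlier step altered a group on the aromatic ring of the arylsulfonyl and left the ring nitrogen's link untouched, whereas this pair shows that a carbonyl group and a sulfonyl group at this spot cannot be told apart in this cell reading, at least with these two small groups that carry no ring. Nothing available here offers an explanation for this result.

The compounds shown leave open whether a longer chain on the sulfonyl, such as propylsulfonyl, a simple acetyl on the nitrogen, or a basic amine carried on a short chain there would separate from compound 3 and compound 4. They also leave open whether the fluorophenylsulfonyl and trifluoromethylphenylsulfonyl groups of compound 1 and compound 2 would read the same alongside the imidazole of compound 4, since those compounds differ from it in more than one place.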